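A few compounds are considered here, and "the series" means these few. Any claim that something is new, unique, unknown or untested is made for them only; others in the source may bear on it.

Three compounds of one series were tested in a functional assay on HCT-15 cells (Homo sapiens) for cytotoxicity, read by sulforhodamine B assay, with a stated time of 72 h; on this read-out higher numbers stand for weaker inhibition of growth and lower numbers for stronger inhibition of growth. Compound 1, `O=C(Nc1ccccc1O)C1CCc2ccccc2N1C(=O)c1ccccc1`, gives 3830 nM in this assay. Compound 2, `O=C(Nc1ccccc1O)C1CCc2ccccc2N1`, gives 5610 nM in this assay. Compound 3, `O=C(Nc1cc(C(F)(F)F)cc(C(F)(F)F)c1)C1CCc2ccccc2N1`, gives 8700 nM in this assay.

Compound 1 and compound 2 share a core and differ in one place: benzoyl in place of hydrogen on a nitrogen on an aromatic ring in a ring. This change brought a 1.5-fold lower number from compound 2 to compound 1 (0.17 log units; within the scatter). Compound 3 carries a different amide partner than compound 2; the difference between the two cores is not broken down here. Compound 3 has the highest number of the three. The number of compound 2 lies within the scatter of it, while the number of compound 1 stands lower by a margin beyond the scatter.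

Compound 4, `O=C(Nc1cc(C(F)(F)F)cc(C(F)(F)F)c1)C1CCc2ccccc2N1C(=O)c1ccccc1`, has not yet been measured. It differs from compound 3 by benzoyl in place of hydrogen on a nitrogen on an aromatic ring in a ring. The place of this change is worded the same for both pairs, so it is the same change as the one from compound 2 to compound 1, made on the core of compound 3 instead; it occurs in two pairs among the compounds shown. Going by the values given here, because compound 2 to compound 1 gave a 1.5-fold lower number from compound 2 to compound 1 (0.17 log units; within the scatter), a step within the scatter, a similarly small step of a 1.5-fold lower number from compound 3 to compound 4 (0.18 log units; within the scatter) is expected here, with no second example of the change on another core to sharpen it. Compound 4 is therefore estimated at 5800 nM in this assay, with the likely range running from 2500 nM to 13000 nM.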

Compound 4, concentration for 50% growth inhibition: 3540 nM
Estimate against measurement, compound 4: 1.6-fold (0.21 log units) above, within the range that was stated.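

In this assay, going by these compounds alone, benzoyl in place of hydrogen on the ring nitrogen gave a 2.5-fold lower number from compound 3 to compound 4 (0.39 log units; beyond the scatter) on the core of compound 3, and only this step, not the earlier one on the core of compound 2, lies beyond the scatter. Even so, the two steps cannot be told apart, so the change lowers the number on both cores by an amount that is consistent from one core to the other: the same change on two cores in this assay, a 1.5-fold lower number (0.17 log units; within the scatter) from compound 2 to compound 1 and a 2.5-fold lower number (0.39 log units; beyond the scatter) from compound 3 to compound 4, 1.7-fold (0.22 log units) apart, within the scatter of two such steps. This rests on just two pairs that differ in their amide partner, so it shows agreement between these two cores only; it does not fix the size of the step or show that it would hold on a third core.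

The compounds shown leave open whether another group on that nitrogen, such as acetyl or benzenesulfonyl, would give a step like that of benzoyl. They also leave open whether the step would persist with an amide partner carrying an amine or a carboxylic acid, and whether it would appear in cell lines other than the one used here.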